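Carbamate for carboxamide: lipophilicity at the assay ceiling

The source may report more compounds than this note shows. Statements on the series, on what has been measured and on what is new or still open speak of the compounds shown alone.

Compound 1 `CNC(=O)c1cc(C)n(Cc2cc(Cl)ccc2OCc2ccccc2)n1`: in a physicochemical assay for lipophilicity, at pH 7.4 (on this read-out higher numbers stand for higher lipophilicity and lower numbers for lower lipophilicity), compound 1 gives > 3.7, which is a limit of the assay. Compound 2 `Cc1cc(C(=O)NCc2cccnc2)nn1Cc1cc(Cl)ccc1OCc1ccccc1`: compound 2 gives > 3.7, again a limit. Compound 3 `Cc1cc(NC(=O)c2c(F)cccc2F)nn1Cc1cc(Cl)ccc1OCc1ccccc1`: compound 3 gives > 3.7, also a limit.

Compound 1 thus stands only at a limit, and so do its two neighbours: the limit of > 3.7 in this assay, at which 3 of the 3 values shown sit. The steps a step that the two limits leave unreadable from compound 1 to compound 2, a step that the two limits leave unreadable from compound 1 to compound 3 and a step that the two limits leave unreadable from compound 2 to compound 3 therefore cannot be sized. Compound 4 `Cc1cc(NC(=O)OC(C)(C)C)nn1Cc1cc(Cl)ccc1OCc1ccccc1` differs from compound 1 by (tert-butoxycarbonyl)amino in place of methylcarbamoyl on an aromatic carbon. For the measured compounds named here, no measured step reads on this change; what the series shows is that every compound so far sits at the ceiling. A step that the limit leaves unreadable from compound 1 to compound 4 in this assay is expected, toward higher numbers, with a limit again the most probable outcome. Compound 4 is estimated at 4.4, within 3.8 to 5.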

Compound 4, distribution coefficient: > 3.7
Compound 4 ended at the assay's limit; the forecaster's own chance of this, stated with the estimate: 85%; the middle value lies beyond the limit too.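

Compound 4 also stands at a limit, so its steps to compound 1, compound 2 and compound 3 cannot be read: the limit of > 3.7 in this assay, at which 4 of the 4 values shown sit. The compounds shown leave open the actual value of each in this assay, and with it the size of every step among them.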